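This account rests on a few compounds, and the source may have more. Where it says the series, first, only, none or still open, it means among the compounds named here.

Compound 1, `NC(=O)C1CCN(c2cc3c(cc2F)c(=O)c(C(=O)NCc2ccccc2)cn3C2CC2)CC1`, was measured in an ADME assay on J774.1 cells (Mus musculus) for cytotoxicity, read by resazurin assay, with a stated time of 48 h (a higher number here means a weaker inhibitor, a lower number a stronger inhibitor), and gave 51200 nM. Compound 2, `NC(=O)C1CCN(c2cc3c(cc2F)c(=O)c(C(=O)NCc2ccco2)cn3C2CC2)CC1`, differs from it only in furan-2-yl in place of phenyl on a saturated chain carbon bound to an amide-type nitrogen. For compound 2 the assay reported only a limit, > 100000 nM. The step is therefore read against (the limit of > 100000 nM in this assay, at which 1 of the 3 values shown sits), and it amounts to an at least 1.9-fold higher number from compound 1 to compound 2 (0.29 log units; that floor lies within the scatter). Compound 3, `CCCCn1cc(C(=O)NCc2ccccc2)c(=O)c2cc(F)c(N3CCC(C(N)=O)CC3)cc21`, carries a different group on the core, (butyl in place of cyclopropyl on an aromatic nitrogen); in this assay compound 3 gives 47000 nM, a step of a 1.1-fold lower number from compound 1 to compound 3 (0.04 log units; within the scatter). Compound 4, `CCCCn1cc(C(=O)NCc2ccco2)c(=O)c2cc(F)c(N3CCC(C(N)=O)CC3)cc21`, is not yet measured. It stands to compound 3 exactly as compound 2 stands to compound 1, with the same change at the same place, (furan-2-yl in place of phenyl on a saturated chain carbon bound to an amide-type nitrogen). Given that the earlier example of this change is recorded as an at least 1.9-fold higher number from compound 1 to compound 2 (0.29 log units; that floor lies within the scatter) and ended at a limit, the step from compound 3 is expected to be of a similar size, a 1.9-fold higher number from compound 3 to compound 4 (0.28 log units; within the scatter). Compound 4 is accordingly estimated at 90000 nM, between 40000 nM and 200000 nM, with a real chance that the assay again reports only a limit.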

Compound 4, half-maximal inhibitory concentration in the J774.1 assay: 41400 nM
Estimate against measurement, compound 4: 2.2-fold (0.34 log units) above; the measured number falls inside the stated range.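

In the J774.1 assay, furan-2-yl in place of phenyl on the core carrying butyl gives a 1.1-fold lower number from compound 3 to compound 4 (0.06 log units; within the scatter). Set beside the earlier example, this neither shows that the change carries over from one core to the other nor shows that it does not: the same change on two cores in the J774.1 assay, an at least 1.9-fold higher number (0.29 log units; that floor lies within the scatter) from compound 1 to compound 2 and a 1.1-fold lower number (0.06 log units; within the scatter) from compound 3 to compound 4; the limit leaves it open whether they differ. In the J774.1 assay, the second step, butyl in place of cyclopropyl with furan-2-yl on the chain carbon, gives an at least 2.4-fold lower number from compound 2 to compound 4 (0.38 log units; beyond the scatter), but this does not establish that butyl acts differently with furan-2-yl than with phenyl: the same change on two cores in the J774.1 assay, a 1.1-fold lower number (0.04 log units; within the scatter) from compound 1 to compound 3 and an at least 2.4-fold lower number (0.38 log units; beyond the scatter) from compound 2 to compound 4; the limit leaves it open whether they differ. In a physicochemical assay for lipophilicity, read by HPLC (on this read-out lower numbers stand for lower lipophilicity and higher numbers for higher lipophilicity), compound 3 gives 2.4 and compound 4 gives 2.4. In the physicochemical assay, furan-2-yl in place of phenyl gives no change at the digits printed from compound 3 to compound 4 (within the scatter).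

From the compounds shown here alone, in the J774.1 assay compound 2 gives > 100000 nM, which is a limit and not a number; the true size of both steps that reach it stays open. Also open, going by these compounds, is how the comparison would read with thiophen-2-yl in place of furan-2-yl, or with a longer chain than butyl on the aromatic nitrogen.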